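Fluoro for Hydroxy on a Tertiary Chain Carbon

The source may report more compounds than this note shows. Statements on the series, on what has been measured and on what is new or still open speak of the compounds shown alone.

Compound 1, `COc1nc(=O)n(C)c(CC(F)(COC(C)=O)COC(C)=O)c1C`, in a functional assay on HeLa cells (Homo sapiens) for antiproliferative activity, read by MTT assay, with a stated time of 72 h (a higher number here means a weaker inhibitor, a lower number a stronger inhibitor), gives > 100000 nM, which is a limit of the assay and not a number.
Compound 2, `COc1nc(=O)n(C)c(CC(O)(COC(C)=O)COC(C)=O)c1C`, in this assay gives > 100000 nM, again a limit.
Compound 3, `CC(=O)OCC(O)(COC(C)=O)Cc1c(C)c(=O)[nH]c(=O)n1C`, in this assay gives > 100000 nM, also a limit.

The two cores differ, and the difference between the core of compound 3 and that of compound 2 is not broken down here. Within the core of compound 2, the change fluoro in place of hydroxy on a saturated chain carbon bound to three saturated chain carbons was made, and the step that the two limits leave unreadable from compound 2 to compound 1 cannot be read, because of the limit of > 100000 nM in this assay, at which 3 of the 3 values shown sit.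

Compound 4, `CC(=O)OCC(F)(COC(C)=O)Cc1c(C)c(=O)[nH]c(=O)n1C`, carries the same change, (fluoro in place of hydroxy on a saturated chain carbon bound to three saturated chain carbons), made on the core of compound 3. Since compound 3 sits at the limit, and since the earlier step from compound 2 to compound 1 stayed at the limit as well, compound 4 is expected to remain there too; the estimated step is a step that the limit leaves unreadable from compound 3 to compound 4. Compound 4 is thus expected to give about 200000 nM in this assay, most likely reported as a limit, with a range from 100000 nM to 1000000 nM.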

Compound 4, half-maximal inhibitory concentration: > 100000 nM
Compound 4 ended at the assay's limit (the forecaster's own chance of this, stated with the estimate: 92%); the middle value is on the limit's open side.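

No new step can be read: the change from hydroxy to fluoro between compound 3 and compound 4 has no readable size, because both compounds sit at a limit of the assay: the limit of > 100000 nM in this assay, at which 4 of the 4 values shown sit.

The compounds shown leave open how fluoro and hydroxy at this place compare in this assay, and what would bring either core to a readable value.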